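Aryl swap on the shared core: compound 3 to compound 4

A few compounds are considered here, and "the series" means these few. Any claim that something is new, unique, unknown or untested is made for them only; others in the source may bear on it.

In a functional assay on Ehrlich cells (Mus musculus) for cytotoxicity (on this read-out lower numbers stand for stronger inhibition and higher numbers for weaker inhibition), compound 3 `COc1ccccc1C1C(C#N)=C(N)N(c2cc(OC)c(OC)c(OC)c2)C2=C1C(=O)CC(C)(C)C2` gives 26600 nM, the higher of the two numbers in hand. Compound 1 `COc1cc(N2C(N)=C(C#N)C(c3ccc([N+](=O)[O-])cc3)C3=C2CC(C)(C)CC3=O)cc(OC)c1OC` gives 25000 nM, and the step of a 1.1-fold higher number from compound 1 to compound 3 (0.03 log units; within the scatter) lies within the scatter. Compound 2 `COc1cc(N2C(N)=C(C#N)C(c3ccccc3O)C3=C2CC(C)(C)CC3=O)cc(OC)c1OC` is reported as "not active" (no number reported) in this assay, so no number is known for it. Compound 4 `COc1cc(N2C(N)=C(C#N)C(c3ccccc3Cl)C3=C2CC(C)(C)CC3=O)cc(OC)c1OC` differs from compound 3 by chloro in place of methoxy on an aromatic carbon. Among the compounds with values here, the one measured step that alters this aryl group, from compound 1 to compound 3, changed nothing beyond the scatter, while compound 2 shows that a change here can also abolish activity. Compound 4 is therefore expected at 27000 nM, range 12000 nM to 60000 nM, an estimated step of a 1.0-fold higher number from compound 3 to compound 4 (0.01 log units; within the scatter) not beyond the scatter.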

Compound 4, half-maximal inhibitory concentration: "not active" (no number reported)
For compound 4 the study gives words and no number; the estimate stays without a comparison.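

In this assay, within the data shown here, compound 4 is reported in words only, so no step from compound 3 can be read. No evidence bearing on this result is available. The compounds shown leave open whether compound 2 and compound 4 have any measurable potency on these cells.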